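The source may hold more compounds than are shown below. What is called first, only, known or untested is meant among the compounds shown, and "the series" means these compounds.

Compound 1 `CCCCCCCCCCCCCCCCCC(=O)OCC1CN(C(=O)c2cc(OC)c(OC)c(OC)c2)CCN1C(=O)c1cc(OC)c(OC)c(OC)c1` gives 45000 nM in a functional assay (Oryctolagus cuniculus) for inhibition of platelet-activating factor receptor (Cavia porcellus); on this read-out lower numbers stand for stronger inhibition and higher numbers for weaker inhibition.
Compound 2 `COc1cc(C(=O)N2CCN(C(=O)c3cc(OC)c(OC)c(OC)c3)C(COC(=O)CC(C)(C)C)C2)cc(OC)c1OC` gives 120 nM in this assay.

Among the two compounds measured in this assay, compound 2 has the lowest number; its nearest neighbour is compound 1, whose number is far higher, a gap that lies well beyond the scatter. The two share the same core and differ only in the chain carried on the oxygen next to the carbonyl group, which makes compound 2 the more useful reference for the next step.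

Compound 3 `CCCN(CCC)C(=O)OCC1CN(C(=O)c2cc(OC)c(OC)c(OC)c2)CCN1C(=O)c1cc(OC)c(OC)c(OC)c1` has not yet been measured in this assay. It differs from compound 2 in one place: dipropylamino in place of neopentyl on a carbonyl carbon. Cut one bond further out, the change reads neopentylcarbonyl to dipropylcarbamoyl. Among the compounds with values here, no step between two measured compounds covers this kind of exchange, so the expectation rests on compound 2 alone.

A small step is expected, a 2.1-fold higher number from compound 2 to compound 3 (0.32 log units; beyond the scatter), toward a somewhat higher number, though it may well stay within the scatter. Compound 3 is estimated at 250 nM in this assay, with a range from 60 nM to 1200 nM.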

Compound 3, half-maximal inhibitory concentration: 380 nM
Compound 3: middle estimate off by 1.5-fold (0.18 log units), on the low side; the range from low to high includes it.
By their numbers in this assay, from the lowest: compound 2; then compound 3; then compound 1.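

In this assay, putting dipropylamino in place of neopentyl on a carbonyl carbon gives a 3.2-fold higher number from compound 2 to compound 3 (0.50 log units; beyond the scatter), a modest step that lies beyond the scatter. This shows that the position can take a nitrogen-linked group with two propyl chains and keep much of the inhibition seen with neopentyl: compound 3 at 380 nM stands far closer to compound 2 than compound 1 does at 45000 nM, so the long chain of compound 1 is not matched by this larger dipropylamino group in its loss of inhibition. No measurement shown here accounts for the step from neopentyl to dipropylamino.

Within the data shown here, the single exchange changes the atom on the carbonyl carbon and the chains at the same time, so it cannot say how much of the step belongs to the nitrogen and how much to the propyl chains. Dimethylamino, dibutylamino or piperidine on the same carbonyl carbon would help to separate the two, and how the number moves across such amines remains open.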